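Sulfonyl aryl swap in the quinoline sulfone series

The compounds below may be only part of what the source reports. "The series", "measured", "known", "first", "only" and "open" are said of these compounds alone.

Compound 1 `O=S(=O)(c1cc(Cl)cc(Cl)c1)c1cnc2cc(F)ccc2c1-c1ccccc1F` is the reference point. Among the measured compounds shown here, in an ADME assay on microsomes from liver (Homo sapiens) for metabolic stability, tested at 2.5 uM (a higher number here means faster removal of the compound, a lower number slower removal), compound 1 gives 0.93 mL/min, the lowest of the two numbers so far. For the measured compounds named here, its only measured neighbour is compound 2 `COc1cccc(-c2c(S(=O)(=O)c3cc(Cl)cc(Cl)c3)cnc3cc(F)ccc23)c1`, which in this assay gives 1.51 mL/min; the step of a 1.6-fold higher number from compound 1 to compound 2 (0.21 log units; within the scatter) changes the aryl on the aromatic carbon of the core, not the aryl on the sulfonyl sulfur.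

Compound 3 `O=S(=O)(c1ccc(F)c(F)c1)c1cnc2cc(F)ccc2c1-c1ccccc1F` differs from compound 1 at the sulfonyl position:

3,4-difluorophenyl in place of 3,5-dichlorophenyl on a sulfonyl sulfur

Going by the values given here, no measured step touches the group on the sulfonyl sulfur, so the one step in hand speaks to this change only by analogy: an aryl swap elsewhere on the same core moved this assay by a 1.6-fold higher number from compound 1 to compound 2 (0.21 log units; within the scatter), a shift inside the scatter. On that basis a step of similar size is expected, without a clear direction, so compound 3 is expected to fall close to compound 1, at a 1.1-fold higher number from compound 1 to compound 3 (0.03 log units; within the scatter). The estimate for compound 3 in this assay is 1 mL/min, with a range from 0.5 mL/min to 2 mL/min; a result outside that range would be the first sign that the sulfonyl aryl matters more than the other aryl did.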

Compound 3, intrinsic clearance in a liver preparation (reported as CLH), per the amount of preparation that the assay uses: 0.79 mL/min
Estimate against measurement, compound 3: 1.3-fold (0.10 log units) above; the range from low to high includes it.
By their numbers in this assay, from the lowest: compounds 3, 1 and 2 (each within the scatter of the next).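

Among the compounds shown here, the first measured change on the sulfonyl sulfur, 3,4-difluorophenyl in place of 3,5-dichlorophenyl, gives in this assay a 1.2-fold lower number from compound 1 to compound 3 (0.07 log units; within the scatter) and so stays inside the scatter. Within this pair, then, the sulfonyl sulfur accepts a different halogen and a different substitution pattern on its phenyl ring without a reading that can be separated from repeat variation, and this position has so far shown no more leverage on the read-out than the aryl swap on the aromatic carbon did in the step from compound 1 to compound 2. No supporting measurement is available that would account for the similarity of compound 1 and compound 3.

Both sulfonyl groups shown are dihalophenyl rings with the same ring size and the same counted features, so it remains open whether a sulfonyl aryl carrying an amine, a carboxylic acid or a longer alkoxy chain would stay as close to compound 1. From the compounds shown here alone, it also remains open whether 3,4-difluorophenyl on the sulfonyl sulfur would read the same alongside 3-methoxyphenyl on the aromatic carbon of the shared core.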